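This account rests on a few compounds, and the source may have more. Where it says the series, first, only, none or still open, it means among the compounds named here.

Measured in a functional assay on HO8910 cells (Homo sapiens) for inhibition, read by MTT assay, with a stated time of 24 h, tested at 10 ug/mL; on this read-out higher numbers stand for more inhibition of growth at the one concentration tested and lower numbers for less inhibition of growth:
- compound 1 `O=C(O)CCCCC(CCSC(=O)c1ccccc1)SC(=O)c1ccccc1`: "not active" (no number reported)
- compound 2 `O=C(CCCCC(S)CCS)Nc1cccc(Cl)c1`: "not active" (no number reported)
- compound 3 `CC(=O)SCCC(CCCCC(=O)Nc1ccc(Cl)cc1)SC(C)=O`: 1.47%

Compound 1 has no single number on this read-out, and its result is reported only as "not active" (no number reported). The next compound to test is compound 4 `O=C(CCCCC(CCSC(=O)c1ccccc1)SC(=O)c1ccccc1)Nc1cccc(Cl)c1`. It keeps the core of compound 1 and turns the acid into an amide, with (3-chlorophenyl)amino in place of hydroxy on a carbonyl carbon. Compound 2 already carries this same group and gives "not active" (no number reported). Compound 3, also an amide, gives 1.47%. From these results, the step in this assay is expected to be small, upward if anything, and probably not beyond the scatter. For compound 4, the estimated inhibition is 5%, with an expected range from 0% to 20%.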

Compound 4, percent growth inhibition at one concentration: "not active" (no number reported)
No number was reported for compound 4, so the estimate cannot be set against anything.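

Compound 1 and compound 4 are both reported only as not active in this assay and so no step can be read between them. No other data bear on this result. As far as these compounds go, whether swapping hydroxy for (3-chlorophenyl)amino changes growth inhibition at all stays open.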